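The source may report more compounds than this note shows. Statements on the series, on what has been measured and on what is new or still open speak of the compounds shown alone.

Measured in an ADME assay on HEK293 cells (Homo sapiens) for cytotoxicity, read by resazurin assay, with a stated time of 72 h; on this read-out higher numbers stand for lower toxicity in this test and lower numbers for higher toxicity in this test:
- compound 1 `CCc1cccc(CNC(=O)c2nc3cccc(COCc4ccc(C(=O)O)cc4)c3c(=O)[nH]2)c1`: > 40000 nM
- compound 2 `CCc1cccc(CNC(=O)c2nc3ccc(OC)c(COCc4ccc(C(=O)O)cc4)c3c(=O)[nH]2)c1`: > 20000 nM
- compound 3 `CCc1cccc(CNC(=O)c2nc3c(Cl)ccc(COCc4ccc(C(=O)O)cc4)c3c(=O)[nH]2)c1`: > 20000 nM

Compound 1 stands only at a limit, > 40000 nM, and not at an exact number. Compound 2 and compound 3 are also known only as limits, with the limit of > 20000 nM in this assay, at which 2 of the 3 values shown sit.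

Compound 4 `CCc1ccc(CNC(=O)c2nc3cccc(COCc4ccc(C(=O)O)cc4)c3c(=O)[nH]2)cc1` carries 4-ethylphenyl in place of 3-ethylphenyl on a saturated chain carbon bound to an amide-type nitrogen.

Among the compounds with values here, two measured steps bear on this: a step that the two limits leave unreadable from compound 1 to compound 2 and a step that the two limits leave unreadable from compound 1 to compound 3. Neither has a readable size, and neither alters the ethylphenyl group. No change beyond the scatter is therefore expected in this assay, in either direction, and the expected size is a number no higher from compound 1 to compound 4 (the limit leaves the size open). Compound 4 is expected at 40000 nM, with an estimated range from 20000 nM to 80000 nM.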

Compound 4, half-maximal cytotoxic concentration: > 20000 nM
Compound 4 was reported as a limit (the forecaster's own chance of this, stated with the estimate: 85%); the middle value lies beyond the limit too.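

Compound 1 and compound 4 are both known only as limits, and the step between them cannot be read. From the compounds shown here alone, whether 4-ethylphenyl in place of 3-ethylphenyl changes the result in this assay stays open.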